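Taking one methyl away from compound 2

The source may report more compounds than this note shows. Statements on the series, on what has been measured and on what is new or still open speak of the compounds shown alone.

Measured in a functional assay on MDA-MB-231 cells (Homo sapiens) for antiproliferative activity, read by MTT assay (a lower number here means a stronger inhibitor, a higher number a weaker inhibitor), with one compound still open:
Compound 1 `CCCC/C=C\CCCCCCCCCc1cc(=O)c2c(O)cc(O)c(C)c2o1`: 6790 nM
Compound 2 `CCCC/C=C\CCCCCCCCCc1cc(=O)c2c(O)c(C)c(O)c(C)c2o1`: > 87000 nM
Compound 3 `CCCCCCCCCCCCCCCc1cc(=O)c2c(O)c(C)c(O)c(C)c2o1`: > 87000 nM
Compound 4 `CCCC/C=C\CCCCCCCCCc1cc(=O)c2c(O)c(C)c(O)cc2o1`: not yet measured

Compound 2 stands at the limit of > 87000 nM in this assay, at which 2 of the 3 values shown sit, so its value is a limit and not a number. Compound 3 also gives only a limit, and a step that the two limits leave unreadable from compound 2 to compound 3 therefore offers no guidance. Compound 4 differs from compound 2 by hydrogen in place of methyl on an aromatic carbon. For the measured compounds named here, the step that bears on this is an at least 12-fold higher number from compound 1 to compound 2 (1.10 log units; beyond the scatter), where a methyl in place of hydrogen on an aromatic carbon was the only change. Going by the values given here, that step concerns the other methyl of compound 2, since compound 1 keeps the one that compound 4 loses, so it is an imperfect guide. A large step toward a lower number is still expected by analogy with it. The expected change is an at least 4.3-fold lower number from compound 2 to compound 4 (0.63 log units; beyond the scatter), and it may not be fully readable if another limit results. Compound 4 is expected at 20000 nM, with an estimated range from 5000 nM to 87000 nM.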

Compound 4, half-maximal inhibitory concentration: 42800 nM
Beside the measured number, compound 4's estimate is 2.1-fold (0.33 log units) below it; low and high end bracket the measured number.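

Removing the methyl on the aromatic carbon para to a hydroxy group gives a readable value in this assay, so compound 2 now has a measured neighbour on this side as well as through its other methyl. The change amounts to an at least 2.0-fold lower number from compound 2 to compound 4 (0.30 log units; that floor lies within the scatter), so this result alone does not establish a real gain on loss of this methyl, unlike the step at the other methyl, which is printed as beyond the scatter. The true size of the step stays unknown because compound 2 carries only a limit: the limit of > 87000 nM in this assay, at which 2 of the 4 values shown sit.

Going by these compounds, it remains open how an ethyl or a methoxy group would read on this same aromatic carbon. Also open, on these data alone, is how the shared core would read with hydrogen in place of both methyl groups.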